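Ortho nitrophenyl in place of a meta trifluoromethylphenyl

A few compounds are considered here, and "the series" means these few. Any claim that something is new, unique, unknown or untested is made for them only; others in the source may bear on it.

The account concerns a small group of quinazoline-type amines and their behaviour in an assay on a protein complex for inhibition of ubiquitin carboxyl-terminal hydrolase 1/WD repeat-containing protein 48 (Homo sapiens), read by fluorescence; on this read-out lower numbers stand for stronger inhibition and higher numbers for weaker inhibition. Compound 1 `Cc1ccc(CNc2nc(-c3ccccc3C(F)(F)F)nc3ccccc23)s1` gives 5100 nM in this assay. Compound 2 `FC(F)(F)c1ccccc1-c1nc(NCc2ccc(-c3ccncc3)cc2)c2ccccc2n1` gives 1900 nM in this assay. Compound 3 `FC(F)(F)c1cccc(-c2nc(NCc3ccc(-c4cccnc4)cc3)c3ccccc3n2)c1` stands apart from these two: in this assay compound 3 was reported as "not active" (no number reported), and no number was obtained for it, so it cannot be placed on the same scale as compound 1 and compound 2 beyond saying that both of those gave a measurable result where compound 3 did not.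

The step from compound 3 to compound 4 `O=[N+]([O-])c1ccccc1-c1nc(NCc2ccc(-c3cccnc3)cc2)c2ccccc2n1` is a single exchange: 2-nitrophenyl in place of 3-(trifluoromethyl)phenyl on an aromatic carbon. Among the compounds with values here, compound 1 and compound 2, which both carry a group on the position next in sequence to the ring junction rather than one position further along, gave measurable values, whereas compound 3 did not; this is the only guide available, and it rests on three compounds only.

No starting number exists for compound 3. Within the data shown here, no size of step can be stated, only a direction: a return to measurable inhibition is expected. For compound 4 the estimate in this assay is 3500 nM, with a range from 800 nM to 20000 nM, and a real chance that only a limit is reported.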

Compound 4, half-maximal inhibitory concentration: 7800 nM
Estimate against measurement, compound 4: 2.2-fold (0.35 log units) below; the range from low to high includes it.
By their numbers in this assay, from the lowest: compound 2; then compounds 1 and 4 (each within the scatter of the next).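

In this assay compound 4 gives 7800 nM, but compound 3 has no number there, so the step between compound 3 and compound 4 cannot be read. The compounds shown leave open how much exchanging 3-(trifluoromethyl)phenyl for 2-nitrophenyl alone changes inhibition. No measurement shown here offers an explanation for this result.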